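A Methyl Group Added: Cytotoxicity Before the Next Measurement

A few compounds are considered here, and "the series" means these few. Any claim that something is new, unique, unknown or untested is made for them only; others in the source may bear on it.

Compound 1, `CC(C)Sc1nc(Cc2c(F)cccc2F)cc(=O)[nH]1`: > 200000 nM
Compound 2, `Cc1c(Cc2c(F)cccc2F)nc(SC(C)C)[nH]c1=O`: > 200000 nM
Compound 3, `CSc1nc(O)cc(C(C)c2c(F)cccc2F)n1`: 20800 nM

Of the compounds shown here, three have so far been tested in a functional assay on MT4 cells (Homo sapiens) for cytotoxicity; on this read-out lower numbers stand for higher toxicity in this test and higher numbers for lower toxicity in this test. For compound 1 the result is a limit of the assay and not a number, > 200000 nM. Compound 2 likewise returns only a limit, > 200000 nM. Within the data shown here, compound 3 is the one compound with a number, 20800 nM. The move from compound 1 to compound 2 is methyl in place of hydrogen on an aromatic carbon; the step it made, a step that the two limits leave unreadable from compound 1 to compound 2, cannot be sized, as the limit of > 200000 nM in this assay, at which 2 of the 3 values shown sit, shows.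

Compound 4, `CSc1nc(O)c(C)c(C(C)c2c(F)cccc2F)n1`, is still to be measured in this assay. It differs from compound 3 by methyl in place of hydrogen on an aromatic carbon. This is the same kind of change as from compound 1 to compound 2, though the surroundings are not identical: in compound 4 the new methyl sits ortho to a hydroxy group (1 heavy atom), ortho to a large group and para to a methylsulfanyl group (2 heavy atoms), whereas in compound 2 it sits ortho to a group of 1 heavy atom, ortho to a group of 9 heavy atoms and para to an isopropylsulfanyl group (4 heavy atoms). The difference between the two cores, that of compound 1 and that of compound 3, is not broken down here.

The expected step is a 1.2-fold higher number from compound 3 to compound 4 (0.08 log units; within the scatter), a small one, resting on compound 3 at 20800 nM and on the unreadable earlier step that the two limits leave unreadable from compound 1 to compound 2. Compound 4 is therefore estimated at 25000 nM, within a range from 8000 nM to 100000 nM.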

Compound 4, half-maximal cytotoxic concentration: > 200000 nM
Compound 4 gave a limit, no number; the forecaster's own chance of this, stated with the estimate: 15%; at least 8.0-fold (0.90 log units) between middle value and limit.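

On the core of compound 3, the methyl in place of hydrogen on an aromatic carbon gives a readable result in this assay: an at least 9.6-fold higher number from compound 3 to compound 4 (0.98 log units; beyond the scatter), and this step is a lower bound of its size, with its true size left unknown. Among these compounds, on the core of compound 1 the same change cannot be sized, because neither end of that step gives a number, and the same ceiling now also caps compound 4: the limit of > 200000 nM in this assay, at which 3 of the 4 values shown sit. Carrying the change from one core to the other is therefore neither confirmed nor contradicted, since a single readable step stands against an unreadable one, and the two results show only that the compounds carrying the methyl on both cores reach the same limit of the assay.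

What the compounds shown leave open is whether the higher number on the core of compound 3 belongs to the methyl itself or would also appear with another group on the same aromatic carbon, such as an ethyl group, an amine or a carboxylic acid. They also leave open whether a longer chain in place of the methylsulfanyl group would change the size of the step in this assay.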